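Ethyl to tert-butyl on a sulfur

The compounds below may be only part of what the source reports. "The series", "measured", "known", "first", "only" and "open" are said of these compounds alone.

In a functional assay on HeLa cells (Homo sapiens) for antiproliferative activity, read by resazurin assay (on this read-out higher numbers stand for weaker inhibition and lower numbers for stronger inhibition), compound 1 (`CSC(=S)SCC(=O)c1ccc(Cl)c(Cl)c1`) gives 6310 nM and compound 2 (`CCSC(=S)SCC(=O)c1ccc(Cl)c(Cl)c1`) gives 7940 nM and so stands level with it within the scatter. Compound 3 (`CC(C)(C)SC(=S)SCC(=O)c1ccc(Cl)c(Cl)c1`) carries tert-butyl in place of ethyl on a sulfur. Among the measured compounds shown here, the one measured step bearing on this is methyl in place of hydrogen on a saturated chain carbon bound to a sulfur (a 1.3-fold higher number from compound 1 to compound 2 (0.10 log units; within the scatter)), which stayed within the scatter. For the measured compounds named here, with that step as the sole guide, no step beyond the scatter is expected in this assay here. The expected step is a 1.1-fold lower number from compound 2 to compound 3 (0.05 log units; within the scatter) by this estimate. Compound 3 is expected at 7000 nM within a range of 3000 nM to 16000 nM in this measurement.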

Compound 3, half-maximal inhibitory concentration: 10000 nM
Beside the measured number, compound 3's estimate is 1.4-fold (0.15 log units) below it; the range from low to high includes it.
By their numbers in this assay, from the lowest: compounds 1, 2 and 3 (each within the scatter of the next).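

In this assay, tert-butyl on this sulfur extends a comparison that had covered only methyl and ethyl, giving a 1.3-fold higher number from compound 2 to compound 3 (0.10 log units; within the scatter) and a 1.6-fold higher number from compound 1 to compound 3 (0.20 log units; within the scatter). Both steps stay within the scatter, so compound 1, compound 2 and compound 3 stand level, and the wider span from methyl to tert-butyl on the sulfur still opens no measurable gap. From the compounds shown here alone, whether an amine, a carboxylic acid or a phenyl ring on this sulfur would keep the numbers at this level remains open. Nothing at hand explains why these three compounds stand level.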